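Side-chain changes and clearance in microsomes: compound 4

A few compounds are considered here, and "the series" means these few. Any claim that something is new, unique, unknown or untested is made for them only; others in the source may bear on it.

Measured compounds:
compound 1 `N[C@H]1CC[C@H](Oc2ccc([C@H]3CC[C@]4(CC3)OOC3(O4)C4CC5CC(C4)CC3C5)cc2)CC1`: < 7 mL.min-1.g-1
compound 2 `NC(=O)C1CCN(Cc2ccc([C@H]3CC[C@]4(CC3)OOC3(O4)C4CC5CC(C4)CC3C5)cc2)CC1`: 10 mL.min-1.g-1
compound 3 `CC(C)(O)CNCCCOc1ccc([C@H]2CC[C@]3(CC2)OOC2(O3)C3CC4CC(C3)CC2C4)cc1`: 8 mL.min-1.g-1

In an ADME assay on microsomes from liver (Homo sapiens) for metabolic stability, read by LC-MS, tested at 1 uM (on this read-out lower numbers stand for slow clearance and higher numbers for fast clearance), the value of compound 1 is a limit, not a number (the limit of < 7 mL.min-1.g-1 in this assay, at which 1 of the 3 values shown sits). Compound 3 holds the lowest of the two numbers, and its nearest neighbour is compound 2 a 1.3-fold lower number from compound 2 to compound 3 (0.10 log units; within the scatter). Compound 4 `CC(C)(CN)Oc1ccc([C@H]2CC[C@]3(CC2)OOC2(O3)C3CC4CC(C3)CC2C4)cc1` differs from compound 3 by 1-(aminomethyl)-1-methylethyl in place of 3-((2-hydroxy-2-methylpropyl)amino)propyl on an oxygen on an aromatic ring. Going by the values given here, two measured steps touch the same side of the shared core: an at least 1.1-fold higher number from compound 1 to compound 3 (0.05 log units; that floor lies within the scatter) and a 1.3-fold lower number from compound 2 to compound 3 (0.10 log units; within the scatter), both within scatter. A step of no more than the scatter is therefore expected for compound 4 in this assay, estimated as a 1.1-fold lower number from compound 3 to compound 4 (0.06 log units; within the scatter). The estimate for compound 4 is 7 mL.min-1.g-1, with a range from 4 mL.min-1.g-1 to 13 mL.min-1.g-1.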

Compound 4, intrinsic clearance in microsomes: < 7 mL.min-1.g-1
Compound 4: no number, only a limit; the forecaster's own chance of this, stated with the estimate: 45%; the middle value sits exactly at the limit.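

In this assay compound 4 gives a limit, not a number: the limit of < 7 mL.min-1.g-1 in this assay, at which 2 of the 4 values shown sit.

The readable steps are an at least 1.1-fold lower number from compound 3 to compound 4 (0.05 log units; that floor lies within the scatter) and an at least 1.4-fold lower number from compound 2 to compound 4 (0.15 log units; that floor lies within the scatter), so on this oxygen 1-(aminomethyl)-1-methylethyl replaces 3-((2-hydroxy-2-methylpropyl)amino)propyl with no step beyond the scatter shown. Compound 1 also carries a limit, and the step from it to compound 4 cannot be read.

Open, from the compounds shown here alone, is the true clearance of compound 4 and compound 1 in this assay. Also open, going by these compounds, is whether a carboxylic acid in place of the amine, or a longer chain on this oxygen, would keep clearance in this range.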